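A few compounds are considered here, and "the series" means these few. Any claim that something is new, unique, unknown or untested is made for them only; others in the source may bear on it.

Compound 1, `CN(C)CCNC(=O)Nc1cc2c(Nc3ccc(F)c(Cl)c3)ncnc2cc1O[C@H]1CCOC1`, gives 806 nM in a functional assay on A-431 cells (Homo sapiens) for antiproliferative activity, read by sulforhodamine B assay, with a stated time of 72 h; a higher number here means a weaker inhibitor, a lower number a stronger inhibitor. Compound 2, `COCCCNC(=O)Nc1cc2c(Nc3ccc(F)c(Cl)c3)ncnc2cc1O[C@H]1CCOC1`, gives 4100 nM in this assay. Compound 3, `CN1CCN(C(=O)Nc2cc3c(Nc4ccc(F)c(Cl)c4)ncnc3cc2O[C@H]2CCOC2)CC1`, gives 675 nM in this assay.

Among these three, compound 3 carries the lowest number. Its gap to compound 1 is small: a 1.2-fold lower number from compound 1 to compound 3 (0.08 log units; within the scatter), a step within the scatter, so the two cannot be ranked. Its gap to compound 2 is larger: a 6.1-fold lower number from compound 2 to compound 3 (0.78 log units; beyond the scatter), a modest step beyond the scatter.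

Compound 4, `COC(=O)/C=C/CNC(=O)Nc1cc2c(Nc3ccc(F)c(Cl)c3)ncnc2cc1O[C@H]1CCOC1`, differs from compound 3 in one place: (3-(methoxycarbonyl)prop-2-en-1-yl)amino in place of 4-methylpiperazin-1-yl on a carbonyl carbon. Among the measured compounds shown here, two measured steps bear on this change. The step of a 5.1-fold higher number from compound 1 to compound 2 (0.71 log units; beyond the scatter) shows that exchanging a dimethylamino-bearing chain for a methoxy-bearing chain at this position raised the number by a modest amount, and a 6.1-fold lower number from compound 2 to compound 3 (0.78 log units; beyond the scatter) shows the same gap in reverse when the methylpiperazinyl group replaces the methoxypropylamino chain. The incoming group of compound 4 is an open chain ending in a methoxycarbonyl group, without the ring nitrogen of compound 3, and in that respect it resembles compound 2 more than compound 1 or compound 3. A modest rise in this assay is therefore expected, of about a 4.4-fold higher number from compound 3 to compound 4 (0.65 log units; beyond the scatter). Compound 4 is estimated to give 3000 nM, with a likely range from 1000 nM to 9000 nM.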

Compound 4, half-maximal inhibitory concentration: 1410 nM
The estimate for compound 4 lay 2.1-fold (0.33 log units) above the measured number, within the range that was stated.
By their numbers in this assay, from the lowest: compounds 3, 1 and 4 (each within the scatter of the next, the first and the last beyond it); then compound 2.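

In this assay, the step of a 2.9-fold lower number from compound 2 to compound 4 (0.46 log units; beyond the scatter) shows that an open chain on this carbonyl carbon need not carry a dimethylamino group or a piperazine ring to lie clear of the number set by the methoxypropyl chain, so the lack of an amine does not by itself fix the number at this position. The new chain does not reach the 4-methylpiperazin-1-yl group, as the modest step of a 2.1-fold higher number from compound 3 to compound 4 (0.32 log units; beyond the scatter) shows, yet the step of a 1.7-fold higher number from compound 1 to compound 4 (0.24 log units; within the scatter) lies within the scatter, so it cannot be ranked against the dimethylamino-bearing chain. No measurement shown here offers an explanation for these differences.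

The change from the methoxypropyl chain alters the double bond and the methoxycarbonyl group together, so the compounds shown do not separate the share of either one. From the compounds shown here alone, it remains open how a saturated chain ending in methoxycarbonyl, a carboxylic acid in place of the methyl ester, or a dimethylamino group at the end of the unsaturated chain would behave at this position.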